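Fluoro substitution on the aryl piperazine of aminothiophene ketones

The source may hold more compounds than are shown below. What is called first, only, known or untested is meant among the compounds shown, and "the series" means these compounds.

Measured so far:
compound 1, `Nc1scc(CN2CCN(c3ccc(Cl)cc3F)CC2)c1C(=O)c1ccc(Cl)cc1`, -81%
compound 2, `Nc1scc(CN2CCN(c3cccc(C(F)(F)F)c3)CC2)c1C(=O)c1ccc(Cl)cc1`, -80%
compound 3, `Nc1scc(CN2CCN(c3cccc(F)c3)CC2)c1C(=O)c1ccc(Cl)cc1`, -82%

In a functional assay on CHO cells with adenosine receptor A1 (Homo sapiens) as the target, read by cAMP accumulation and immunoassay, with a stated time of 6 min, tested at 10 uM (a higher number here means a weaker effect of the compound at the concentration tested, a lower number a stronger effect), compound 3 gives -82%, the lowest of the three numbers, though its steps to the others are within the scatter: a number 1 percentage points lower from compound 1 to compound 3 (within the scatter), and a number 2 percentage points lower from compound 2 to compound 3 (within the scatter). Likewise a number 1 percentage points higher from compound 1 to compound 2 (within the scatter). Across three different aryl groups on the amine nitrogen in the ring, the read-out in this assay has not moved beyond the scatter.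

Compound 4, `Nc1scc(CN2CCN(c3cc(F)cc(F)c3)CC2)c1C(=O)c1ccc(Cl)cc1`, has not been measured in this assay. It differs from compound 3 by fluoro in place of hydrogen on an aromatic carbon; cut one bond further out, the change reads 3-fluorophenyl to 3,5-difluorophenyl. For the measured compounds named here, no measured step adds a second fluoro to this ring, so the step from compound 1 to compound 2, from compound 1 to compound 3 and from compound 2 to compound 3 bear on it only indirectly: all three swap the aryl group with no movement beyond the scatter. For compound 4 the expected step is therefore a number 1 percentage points higher from compound 3 to compound 4 (within the scatter), none beyond the scatter. Compound 4 is estimated at -81%, between -92% and -70%.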

Compound 4, a percentage reported as activity, at one concentration (the size of the read-out at that concentration, not a potency): -79%
Beside the measured number, compound 4's estimate is 2 percentage points below it, within the range that was stated.
By their numbers in this assay, from the lowest: compounds 3, 1, 2 and 4 (each within the scatter of the next).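

In this assay, the step that adds a fluoro to the aryl ring rather than exchanging the whole aryl group is also small: a number 3 percentage points higher from compound 3 to compound 4 (within the scatter). The 3,5-difluorophenyl group likewise stays close to the two other aryl groups, with a number 1 percentage points higher from compound 2 to compound 4 (within the scatter) and a number 2 percentage points higher from compound 1 to compound 4 (within the scatter), so this read-out at a single concentration does not separate any of the four aryl groups, and a fluoro at this aromatic carbon, meta to a fluoro group, leaves it inside the scatter. Nothing available accounts for this flat result, and no cause can be assigned.

Still open, from the compounds shown here alone, is whether an amine, a carboxylic acid or a methoxy group on this carbon would move the read-out beyond the scatter. Going by these compounds, all four compounds also share the same core and the same chlorophenyl ketone, so the effect of changes elsewhere remains unknown.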